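A few compounds are considered here, and "the series" means these few. Any claim that something is new, unique, unknown or untested is made for them only; others in the source may bear on it.

Among the measured compounds shown here, compound 2 `COC(=O)N1C[C@H](Cc2ccc(Cl)cc2)N(C2CCN(c3n[nH]c(N)n3)CC2)C[C@@H]1C` gives 461 nM in an assay on isolated protein for inhibition of chitotriosidase-1 (Mus musculus), read by fluorescence, with a stated time of 60 min (a lower number here means a stronger inhibitor, a higher number a weaker inhibitor), the highest of the two numbers so far; compound 1 `C[C@H]1CN(C2CCN(c3n[nH]c(N)n3)CC2)[C@@H](Cc2ccc(Cl)cc2)CN1CC(=O)N(C)C` gives 24 nM in this assay. For the measured compounds named here, the one measured step, a 19-fold higher number from compound 1 to compound 2 (1.28 log units; beyond the scatter), shows that exchanging the group on this ring nitrogen can move the number a long way. Compound 3 `C[C@H]1CN(C2CCN(c3n[nH]c(N)n3)CC2)[C@@H](Cc2ccc(Cl)cc2)CN1S(C)(=O)=O` carries methylsulfonyl in place of methoxycarbonyl on an amine nitrogen in a ring. Going by the values given here, no measured step covers a methylsulfonyl at this position, so the expectation rests on the size of a 19-fold higher number from compound 1 to compound 2 (1.28 log units; beyond the scatter) alone and stays wide. Compound 3 is expected to give about 300 nM in this assay, within 70 nM to 1300 nM, an expected step of a 1.5-fold lower number from compound 2 to compound 3 (0.19 log units; within the scatter).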

Compound 3, half-maximal inhibitory concentration: 1010 nM
Estimate against measurement, compound 3: 3.4-fold (0.53 log units) below; measured number inside the range.
By their numbers in this assay, from the lowest: compound 1; then compound 2; then compound 3.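

In this assay, methylsulfonyl in place of methoxycarbonyl gives a 2.2-fold higher number from compound 2 to compound 3 (0.34 log units; beyond the scatter), so even these two groups on this ring nitrogen, with the same heavy-atom count, are told apart beyond the scatter, though only modestly. Against (dimethylcarbamoyl)methyl, the same group gives a 42-fold higher number from compound 1 to compound 3 (1.62 log units; beyond the scatter), which leaves that group with the lowest number of the three. Nothing at hand explains either step. The compounds shown leave open how an amine, a carboxylic acid or a longer chain ending in the dimethylamide would compare with compound 1 on this nitrogen.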